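The source may hold more compounds than are shown below. What is called first, only, known or untested is meant among the compounds shown, and "the series" means these compounds.

Measured compounds:
compound 1, `COC(CCc1ccccc1)c1ccccc1OCC(O)CN(C(C)C)C(C)C`, 660 nM
compound 2, `CCCNCC(O)COc1ccc(OCc2ccccc2)cc1C(=O)CCc1ccccc1`, 110 nM

Both numbers come from a functional assay on CCRF-CEM/VCR-1000 cells (Homo sapiens) for inhibition (on this read-out higher numbers stand for weaker inhibition and lower numbers for stronger inhibition), and there are only these two to go on. Compound 1 stands at the higher of the two, so it is the weaker inhibitor of the pair; compound 2 sits at a number that is lower by a gap beyond the usual scatter. The two compounds differ in many places at once, so this gap cannot be tied to any single change.

Compound 3, `COC(CCc1ccccc1)c1ccccc1OCC(O)CN1CCCCC1`, is built from compound 1 by one change: piperidin-1-yl in place of diisopropylamino on a saturated chain carbon, two bonds along the chain from an oxygen on a saturated carbon. The two amine groups are close in size, and the only real difference is that the six carbon and nitrogen atoms of the new group are tied into a ring. Among the compounds with values here, no measured pair shows this swap, so any expectation rests on how small it is. A step of about a 1.2-fold lower number from compound 1 to compound 3 (0.08 log units; within the scatter) is expected, which is to say none beyond the scatter, with compound 3 remaining near compound 1 rather than approaching compound 2. On that basis compound 3 is estimated at 550 nM in this assay, with a range from 200 nM to 1500 nM.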

Compound 3, half-maximal inhibitory concentration: 770 nM
For compound 3 the middle estimate is 1.4-fold (0.15 log units) below the measured one; the range from low to high includes it.
By their numbers in this assay, from the lowest: compound 2; then compounds 1 and 3 (each within the scatter of the next).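

In this assay, within the data shown here, putting piperidin-1-yl in place of diisopropylamino gives a 1.2-fold higher number from compound 1 to compound 3 (0.07 log units; within the scatter), and this is the first pair here that differs in only one place. At this position, on a saturated chain carbon, two bonds along the chain from an oxygen on a saturated carbon, the open-chain amine group and the six-membered ring therefore cannot be told apart in this read-out, even though the ring group has one heavy atom fewer and its atoms are tied together. Nothing in the available data explains why the two groups read alike.

On these data alone, whether this holds for other groups at the same place remains open, for example morpholin-4-yl, with an oxygen in the ring, the smaller pyrrolidin-1-yl ring, or a plain primary amine. Compound 2 still differs from compound 1 and compound 3 in many places at once, so these compounds do not show which of its features goes with its lower number.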